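Swapping a Nitrile Chain for Triazole: Solubility Outlook

The compounds below may be only part of what the source reports. "The series", "measured", "known", "first", "only" and "open" are said of these compounds alone.

Compound 1 `Cc1ncc2c(N)c(C#N)c(N)nc2n1`: 783000 nM
Compound 2 `N#Cc1c(N)nc2nc(C3CCCCC3)ncc2c1N`: 81000 nM
Compound 3 `CC(C)(C)c1nc(CCCCCC#N)c2c(N)c(C#N)c(N)nc2n1`: 6000 nM

Of the compounds shown here, three built on a shared core have been measured in a physicochemical assay for solubility, in phosphate buffer, with a stated time of 18 h; on this read-out higher numbers stand for higher solubility and lower numbers for lower solubility. Compound 3 holds the lowest number of the three; its nearest neighbour is compound 2, and the furthest from it is compound 1, both standing well above it, beyond the scatter in each case.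

Compound 4 `CC(C)(C)c1nc(-c2ncn[nH]2)c2c(N)c(C#N)c(N)nc2n1` has not yet been measured in this assay. It differs from compound 3 in one place: 1H-1,2,4-triazol-5-yl in place of 5-cyanopentyl on an aromatic carbon. Going by the values given here, only one measured step exists among the three compounds, a 9.7-fold lower number from compound 1 to compound 2 (0.99 log units; beyond the scatter), and it concerns cyclohexyl in place of methyl, a different kind of change from the one leading to compound 4. It does show that adding a large carbon group on that part of the core lowered the number. The change to compound 4 runs the other way, removing a seven-heavy-atom chain and bringing in a small five-membered aromatic ring carrying a hydrogen-bond donor. On this thin basis, a step upward in this assay is expected for compound 4, of the order of a 4.2-fold higher number from compound 3 to compound 4 (0.62 log units; beyond the scatter), beyond the scatter but well short of the gap between compound 3 and compound 1.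

Compound 4 is therefore estimated at 25000 nM in this assay, with a range from 8000 nM to 80000 nM.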

Compound 4, solubility: 64500 nM
Compound 4: the middle estimate sits 2.6-fold (0.41 log units) below what was measured, and the stated range covers the measured number.
By their numbers in this assay, from the lowest: compound 3; then compounds 4 and 2 (each within the scatter of the next); then compound 1.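

In this assay, 1H-1,2,4-triazol-5-yl in place of 5-cyanopentyl on an aromatic carbon next to the ring nitrogen gives an 11-fold higher number from compound 3 to compound 4 (1.03 log units; beyond the scatter), a large step beyond the scatter. The only earlier step, a 9.7-fold lower number from compound 1 to compound 2 (0.99 log units; beyond the scatter), concerned cyclohexyl in place of methyl, so this is the first single change shown at this position, and it shows that, with the tert-butyl group held fixed, the group at this position alone can move the solubility number by a large step. No measurement shown here accounts for the size or the direction of this step.

The single swap removes a chain and brings in a ring at once, so the compounds shown leave open how much of the step goes with the loss of 5-cyanopentyl and how much with the arrival of 1H-1,2,4-triazol-5-yl; a pentyl chain without its nitrile, a phenyl ring or an imidazole at this position would begin to separate the two. Also open, going by these compounds, is whether the same swap gives a step of similar size with methyl or cyclohexyl in place of the tert-butyl group.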